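Octyl replacing 4-methoxy-2-nitrophenyl in an antiproliferative series

This account rests on a few compounds, and the source may have more. Where it says the series, first, only, none or still open, it means among the compounds named here.

Working notes on the series, read in a functional assay on A549 cells (Homo sapiens) for antiproliferative activity, read by MTT assay; a lower number here means a stronger inhibitor, a higher number a weaker inhibitor. Compound 1 `COc1ccc(-n2cc(COc3ccc(/C=C/C(=O)c4ccc5c(c4O)CCC(C)(C)O5)cc3)nn2)c([N+](=O)[O-])c1` offers no number to start from: in this assay compound 1 is reported as "not active" (no number reported). Its position is therefore known only as a qualitative result. Compound 2 `CCCCCCCCn1cc(COc2ccc(/C=C/C(=O)c3cc4c(cc3O)OC(C)(C)CC4)cc2)nn1`, an octyl compound, is the only one of the series with a number, and in this assay compound 2 gives 50800 nM.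

The next compound is compound 3 `CCCCCCCCn1cc(COc2ccc(/C=C/C(=O)c3ccc4c(c3O)CCC(C)(C)O4)cc2)nn1`, which has octyl in place of 4-methoxy-2-nitrophenyl on an aromatic nitrogen of the five-membered aromatic ring with 3 nitrogen: octyl in place of 4-methoxy-2-nitrophenyl on an aromatic nitrogen.

Going by the values given here, no measured step covers this exchange, so its size cannot be derived from the data. The expected direction in this assay is towards a stronger result, a move from no number to a measurable one, though only a modest move. That expectation rests on compound 2 at 50800 nM, which shows that a number can be obtained but not a strong one. A second result without a number remains possible.

Compound 3 is expected at about 30000 nM, with an estimated range of 8000 nM to 100000 nM.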

Compound 3, half-maximal inhibitory concentration: "not active" (no number reported)
For compound 3 the study gives words and no number; there is nothing to compare the estimate with.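

With compound 1 and compound 3 both reported in this assay only in words, no new step can be read for octyl replacing 4-methoxy-2-nitrophenyl. No supporting data bear on this result. The compounds shown leave open how far compound 1 and compound 3 each lie from a measurable value, and whether this exchange alters activity at all.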